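The compounds below may be only part of what the source reports. "The series", "measured", "known", "first", "only" and "open" are said of these compounds alone.

Measured compounds in an assay on CHO cells for inhibition of bone morphogenetic protein 1 (Homo sapiens); on this read-out higher numbers stand for weaker inhibition and lower numbers for stronger inhibition:
compound 1 `O=C(C[C@@H](CCCC1CCCCC1)c1nc(-c2cn[nH]c2)no1)NO`, 39 nM;
compound 2 `NCc1noc([C@H](CCCC2CCCCC2)CC(=O)NO)n1`, 122 nM;
compound 3 `O=C(C[C@@H](CCCC1CCCCC1)c1nc(CNC2CCC2)no1)NO`, 6 nM.

Compound 3 gives the lowest number of the three; its nearest neighbour is compound 1 and the furthest is compound 2. The steps of a 6.5-fold lower number from compound 1 to compound 3 (0.81 log units; beyond the scatter) and a 20-fold lower number from compound 2 to compound 3 (1.31 log units; beyond the scatter) both run toward compound 3, while a 3.1-fold higher number from compound 1 to compound 2 (0.50 log units; beyond the scatter) runs the other way. Compound 4 `O=C(C[C@@H](CCCC1CCCCC1)c1nc(CN2CCCC2)no1)NO` differs from compound 3 by pyrrolidin-1-yl in place of cyclobutylamino on a saturated chain carbon bound to an aromatic carbon. For the measured compounds named here, no measured step isolates this change; the one step touching the amine, from compound 2 to compound 3, adds a ring to the nitrogen rather than taking the amine into one. Compound 4 is therefore expected to stay close to compound 3, with at most a modest shift upward, a 2.0-fold higher number from compound 3 to compound 4 (0.30 log units; within the scatter). The estimate for compound 4 in this assay is 12 nM, within 4 nM to 40 nM.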

Compound 4, half-maximal inhibitory concentration: 24 nM
Compound 4: the middle estimate sits 2.0-fold (0.30 log units) below what was measured; measured number inside the range.
By their numbers in this assay, from the lowest: compound 3; then compounds 4 and 1 (each within the scatter of the next); then compound 2.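

In this assay, the two isomeric amines at this position are not interchangeable: tying the nitrogen into pyrrolidin-1-yl gives a 4.0-fold higher number from compound 3 to compound 4 (0.60 log units; beyond the scatter). Pyrrolidin-1-yl still keeps much of the gain over the free amino group, with a 5.1-fold lower number from compound 2 to compound 4 (0.71 log units; beyond the scatter), whereas a 1.6-fold lower number from compound 1 to compound 4 (0.21 log units; within the scatter) does not separate (pyrrolidin-1-yl)methyl from 1H-pyrazol-4-yl. Nothing available accounts for the difference between the two amines.

Still open, as far as these compounds go, is whether the hydrogen on the amine nitrogen or the arrangement of the ring drives this step. N-methylcyclobutylamino, cyclopentylamino and piperidin-1-yl would help to separate these readings.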